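Chloro in Place of Fluoro: From Compound 1 to Compound 4

The source may hold more compounds than are shown below. What is called first, only, known or untested is meant among the compounds shown, and "the series" means these compounds.

Of the compounds shown here, three sharing one core have been measured in a functional assay on HT-29 cells (Homo sapiens) for cytotoxicity, read by MTT assay, with a stated time of 72 h; a higher number here means a weaker inhibitor, a lower number a stronger inhibitor. Compound 1 `CN(C)CCn1cnnc1-c1cc(Oc2ccc(NC(=O)N/N=C/c3ccc(F)cc3Cl)cc2F)ccn1` gives 510 nM, the lowest of the three numbers. Compound 2 `CN(C)CCn1cnnc1-c1cc(Oc2ccc(NC(=O)N/N=C/c3c[nH]c4ccccc34)cc2F)ccn1`, which carries 1H-indol-3-yl in place of 2-chloro-4-fluorophenyl on a carbon with a double bond to nitrogen, gives 1300 nM, a step of a 2.5-fold higher number from compound 1 to compound 2 (0.41 log units; beyond the scatter). Compound 3 `CN(C)CCn1cnnc1-c1cc(Oc2ccc(NC(=O)N/N=C/c3ccccc3O[N+](=O)[O-])cc2F)ccn1`, with 2-(nitrooxy)phenyl at that same carbon, gives 950 nM; the step is a 1.9-fold higher number from compound 1 to compound 3 (0.27 log units; within the scatter). Between compound 2 and compound 3 the step is a 1.4-fold lower number from compound 2 to compound 3 (0.14 log units; within the scatter).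

Compound 4 `CN(C)CCn1cnnc1-c1cc(Oc2ccc(NC(=O)N/N=C/c3ccc(Cl)cc3Cl)cc2F)ccn1` is not yet measured. It differs from compound 1 in one place: chloro in place of fluoro on an aromatic carbon. This is a far smaller change than either of the measured ones, which replaced the whole 2-chloro-4-fluorophenyl group. Neither measured step therefore bears on it directly. Among the measured compounds shown here, they show only that replacing the whole group gave a higher number for compound 2, beyond the scatter, and a number within the scatter for compound 3. Exchanging one halogen for another on the same ring is expected to move the number less than that, most likely staying within the scatter. Compound 4 is therefore estimated at 600 nM, with a range from 300 nM to 1200 nM. That expectation corresponds to a step of a 1.2-fold higher number from compound 1 to compound 4 (0.07 log units; within the scatter).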

Compound 4, half-maximal inhibitory concentration: 390 nM
Beside the measured number, compound 4's estimate is 1.5-fold (0.19 log units) above it; measured number inside the range.
By their numbers in this assay, from the lowest: compounds 4, 1, 3 and 2 (each within the scatter of the next, the first and the last beyond it).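

In this assay, chloro in place of fluoro on this aromatic carbon, para to a large group and meta to a chloro group, is the first change shown that leaves the rest of the ring untouched, and it gives a 1.3-fold lower number from compound 1 to compound 4 (0.12 log units; within the scatter), so these two halogens cannot be told apart at this position in this assay. The comparisons with the other two ring systems add something new: 2,4-dichlorophenyl gives a 2.4-fold lower number from compound 3 to compound 4 (0.39 log units; beyond the scatter) and a 3.3-fold lower number from compound 2 to compound 4 (0.52 log units; beyond the scatter), and the first of these steps lies beyond the scatter, whereas the step from 2-chloro-4-fluorophenyl to 2-(nitrooxy)phenyl did not. Nothing measured here accounts for how these numbers compare, so the result can be described but not explained.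

The compounds shown leave open whether a group of a different kind on this same aromatic carbon, such as methoxy, an amine or a carboxylic acid, would also stay within the scatter of compound 1. They also leave open what the chloro group on the same ring contributes, since it stays in place in both compound 1 and compound 4.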